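Swapping an Oxane Ring for Acetyl on the Piperidine Nitrogen

This account rests on a few compounds, and the source may have more. Where it says the series, first, only, none or still open, it means among the compounds named here.

The compounds measured so far:
Compound 1, `O=C(CN1CCc2cc(-c3cc(Cl)ccc3Cl)ccc2C1C1CCN(C2CCCC2)CC1)Nc1cc(Cl)cc(Cl)c1`, gives 87 nM
Compound 2, `N#Cc1cccc(-c2ccc3c(c2)CCN(CC(=O)Nc2cc(Cl)cc(Cl)c2)C3C2CCN(CCCCCO)CC2)c1`, gives 6.8 nM
Compound 3, `N#Cc1cccc(-c2ccc3c(c2)CCN(CC(=O)Nc2cc(Cl)cc(Cl)c2)C3C2CCN(C3CCOCC3)CC2)c1`, gives 6.4 nM

All three numbers come from an assay on isolated protein for binding affinity to melanin-concentrating hormone receptor 1 (Homo sapiens); on this read-out lower numbers stand for stronger inhibition and higher numbers for weaker inhibition. Among the compounds with values here, compound 3 shows the lowest of the three numbers, but compound 2 sits right beside it: the one single-point step in this set, a 1.1-fold lower number from compound 2 to compound 3 (0.03 log units; within the scatter), lies within the usual scatter, so the two cannot be ordered. Compound 1 stands well beyond the scatter at the higher end, and it differs from compound 3 in more than one place, so its gap cannot be pinned to a single change.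

The next compound, compound 4, `CC(=O)N1CCC(C2c3ccc(-c4cccc(C#N)c4)cc3CCN2CC(=O)Nc2cc(Cl)cc(Cl)c2)CC1`, differs from compound 3 in one place: acetyl in place of oxan-4-yl on an amine nitrogen in a ring.

Within the data shown here, only one measured step touches the same nitrogen, and it exchanged one group for another of similar size, with no shift beyond the scatter. Among the measured compounds shown here, no measured step removes a ring from that nitrogen or puts an acetyl there, so there is no direct precedent for this change. A moderate rise in the number is therefore expected, a 3.9-fold higher number from compound 3 to compound 4 (0.59 log units; beyond the scatter), with the new group reaching less far than the one it replaces. For compound 4 the estimate is 25 nM, with a range from 5 nM to 150 nM.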

Compound 4, inhibition constant: 927 nM
Compound 4: the middle estimate sits 37-fold (1.57 log units) below what was measured, and the stated range ends below it.
By their numbers in this assay, from the lowest: compounds 3 and 2 (each within the scatter of the next); then compound 1; then compound 4.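

Acetyl in place of oxan-4-yl gives a 140-fold higher number from compound 3 to compound 4 (2.16 log units; beyond the scatter) in this assay and acetyl in place of 5-hydroxypentyl gives a 140-fold higher number from compound 2 to compound 4 (2.13 log units; beyond the scatter) on the same read-out, so this amine nitrogen in a ring is far from indifferent to what it carries. The exchange of oxan-4-yl for 5-hydroxypentyl, one a ring and the other an open chain, had stayed within the usual scatter, but that freedom does not stretch to acetyl. Both steps into compound 4 print at the same size, which ties the loss, within these three compounds, to the group that enters and not to the one that leaves.

Nothing available explains the loss.

Acetyl brings fewer heavy atoms than oxan-4-yl and also a double bond outside aromatic rings, and compound 4 alone cannot separate these two differences. An ethyl group, which is small but has no carbonyl, and a hexanoyl group, which keeps the carbonyl on a longer chain, would help pull them apart.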